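Swapping a Sulfonyl Aryl Group in Leukemia Cell Growth Inhibitors

This account rests on a few compounds, and the source may have more. Where it says the series, first, only, none or still open, it means among the compounds named here.

Of the compounds shown here, three have so far been tested in a functional assay on RS4-11 cells (Homo sapiens) for inhibition, read by CCK-8 assay, with a stated time of 48 h, tested at 20 uM; on this read-out higher numbers stand for more inhibition of growth at the one concentration tested and lower numbers for less inhibition of growth. Compound 1 `COc1ccc(Cc2nnc(NC(=O)/C(C#N)=C/c3ccccc3OS(=O)(=O)c3ccccc3[N+](=O)[O-])s2)cc1` gives 68%, compound 2 `COc1ccc(Cc2nnc(NC(=O)/C(C#N)=C/c3ccccc3OS(=O)(=O)c3ccc(Cl)cc3)s2)cc1` gives 79%, and compound 3 `N#C/C(=C\c1ccccc1OS(=O)(=O)c1ccccc1[N+](=O)[O-])C(=O)Nc1nnc(Cc2ccc(F)cc2)s1` gives 61%. Compounds 1 and 2 differ by 4-chlorophenyl in place of 2-nitrophenyl on a sulfonyl sulfur, and this change made a step of a number 11 percentage points higher from compound 1 to compound 2 (beyond the scatter). Compounds 1 and 3 differ by fluoro in place of methoxy on an aromatic carbon, with a step of a number 7 percentage points lower from compound 1 to compound 3 (within the scatter).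

Compound 4 `N#C/C(=C\c1ccccc1OS(=O)(=O)c1ccc(Cl)cc1)C(=O)Nc1nnc(Cc2ccc(F)cc2)s1` has not yet been measured. It differs from compound 3 by 4-chlorophenyl in place of 2-nitrophenyl on a sulfonyl sulfur, the same change seen between compounds 1 and 2, at the same place on the structure. A similar step is therefore expected, a number 11 percentage points higher from compound 3 to compound 4 (beyond the scatter) in this assay, beside the earlier a number 11 percentage points higher from compound 1 to compound 2 (beyond the scatter), resting on that single prior example only. Compound 4 is accordingly estimated at 72%, most likely between 62% and 82%.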

Compound 4, percent growth inhibition at one concentration: 68%
Beside the measured number, compound 4's estimate is 4 percentage points above it, and the stated range covers the measured number.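

In this assay the swap to 4-chlorophenyl gives a number 7 percentage points higher from compound 3 to compound 4 (within the scatter) on the core of compound 3, and this agrees with the same swap on the core of compound 1: the same change on two cores in this assay, a number 11 percentage points higher (beyond the scatter) from compound 1 to compound 2 and a number 7 percentage points higher (within the scatter) from compound 3 to compound 4, 4 percentage points apart, within the scatter of two such steps. Fluoro in place of methoxy gives a number 11 percentage points lower from compound 2 to compound 4 (beyond the scatter) and likewise agrees with its earlier step: the same change on two cores in this assay, a number 7 percentage points lower (within the scatter) from compound 1 to compound 3 and a number 11 percentage points lower (beyond the scatter) from compound 2 to compound 4, 4 percentage points apart, within the scatter of two such steps. Both changes therefore appear to carry from one core to the other, but this rests on four compounds tested at a single concentration, and the step to compound 4 on its own cannot be told apart from scatter.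

The compounds shown leave open whether an unsubstituted phenyl on the sulfonyl sulfur would follow the same course. They also leave open what an amine or a carboxylic acid would do in place of the fluoro.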